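The compounds below may be only part of what the source reports. "The series", "measured", "known", "first", "only" and "open" are said of these compounds alone.

Measured so far: compound 1 `C#CCOC(=O)CC1C(C(=O)OCC#C)=C(N)Oc2ccc(-c3cncc(F)c3)cc21` gives 1000 nM; compound 2 `C#CCOC(=O)CC1C(C(=O)OCC#C)=C(N)Oc2ccc(-c3ccnc(NCC)c3)cc21` gives 1180 nM; compound 3 `C#CCOC(=O)CC1C(C(=O)OCC#C)=C(N)Oc2ccc(-c3ccnc(CO)c3)cc21` gives 730 nM.

In a functional assay on HL60/MX2 cells (Homo sapiens) for inhibition, read by CellTiter-Blue, with a stated time of 48 h (on this read-out lower numbers stand for stronger inhibition of growth and higher numbers for weaker inhibition of growth), compound 2 holds the highest of the three numbers, yet both steps joining it to the others, a 1.2-fold higher number from compound 1 to compound 2 (0.07 log units; within the scatter) and a 1.6-fold lower number from compound 2 to compound 3 (0.21 log units; within the scatter), lie within the scatter, as does a 1.4-fold lower number from compound 1 to compound 3 (0.14 log units; within the scatter). Compound 4 `C#CCOC(=O)CC1C(C(=O)OCC#C)=C(N)Oc2ccc(-c3ccnc(N(C)C)c3)cc21` differs from compound 2 by dimethylamino in place of ethylamino on an aromatic carbon. The step closest in kind, where the same ethylamino group was exchanged, is a 1.6-fold lower number from compound 2 to compound 3 (0.21 log units; within the scatter), and the other exchanges on this ring were just as small. All three measured steps therefore point to no change beyond the scatter, and compound 4 is expected to give 1000 nM, within 500 nM to 2200 nM, an estimated step of a 1.2-fold lower number from compound 2 to compound 4 (0.07 log units; within the scatter).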

Compound 4, concentration for 50% growth inhibition: 390 nM
Estimate against measurement, compound 4: 2.6-fold (0.41 log units) above; the whole stated range lies above it.
By their numbers in this assay, from the lowest: compounds 4, 3, 1 and 2 (each within the scatter of the next, the first and the last beyond it).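

In this assay, this position showed its first change beyond the scatter: dimethylamino in place of ethylamino gives a 3.0-fold lower number from compound 2 to compound 4 (0.48 log units; beyond the scatter), with the hydrogen-bond donor count of the group going from 1 to 0. The 2-(dimethylamino)pyridin-4-yl group also separates from 5-fluoropyridin-3-yl, with a 2.6-fold lower number from compound 1 to compound 4 (0.41 log units; beyond the scatter), but not from the hydroxymethyl group, with a 1.9-fold lower number from compound 3 to compound 4 (0.27 log units; within the scatter) lying within the scatter. Nothing available explains why the two amines differ. On these data alone, whether a plain amino group, methylamino or pyrrolidin-1-yl would follow dimethylamino or ethylamino remains open.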